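The source may report more compounds than this note shows. Statements on the series, on what has been measured and on what is new or still open speak of the compounds shown alone.

Measured in a functional assay on A2780 cells (Homo sapiens) for antiproliferative activity, read by fluorescence, with a stated time of 72 h; a higher number here means a weaker inhibitor, a lower number a stronger inhibitor:
- Compound 1 `CC(=O)N1CCN(C(=O)N2Cc3c(NC(=O)c4ccc(F)cc4)n[nH]c3C2(C)C)CC1`: > 10000 nM, a limit
- Compound 2 `CN1CCC(C(=O)N2Cc3c(NC(=O)c4cccs4)n[nH]c3C2(C)C)CC1`: 30 nM
- Compound 3 `CN1CCC(C(=O)N2Cc3c(NC(=O)c4ccco4)n[nH]c3C2(C)C)CC1`: > 5000 nM, a limit

Compound 1 has only a limit, > 10000 nM, and no exact number. Compound 4 `CN1CCN(C(=O)N2Cc3c(NC(=O)c4ccc(F)cc4)n[nH]c3C2(C)C)CC1` keeps the core of compound 1 and changes one group: methyl in place of acetyl on an amine nitrogen in a ring.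

For the measured compounds named here, no measured step covers this change. Going by the values given here, the one measured step, an at least 160-fold higher number from compound 2 to compound 3 (2.22 log units; beyond the scatter), concerns a different group, but it shows that a single change can matter greatly here. Compound 2 also has a methyl on an amine nitrogen in a ring and gives 30 nM. Compound 3 has that methyl too, yet it goes against this hint with its limit, > 5000 nM.

A large step toward a stronger inhibitor is therefore expected, though with wide uncertainty. The expected change is an at least 33-fold lower number from compound 1 to compound 4 (1.52 log units; beyond the scatter). For compound 4 the estimate is 300 nM, with an expected range of 40 nM to 3000 nM.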

Compound 4, half-maximal inhibitory concentration: 180 nM
Compound 4: middle estimate off by 1.7-fold (0.22 log units), on the high side; measured number inside the range.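

Putting 4-methylpiperazin-1-yl in place of 4-acetylpiperazin-1-yl gives an at least 55-fold lower number from compound 1 to compound 4 (1.74 log units; beyond the scatter) in this assay. So the group on this amine nitrogen, which no earlier pair varied, matters greatly on this core. Compound 1 carries only a limit, so the true size of this step stays unknown: the limit of > 10000 nM in this assay, at which 1 of the 4 values shown sits.

As far as these compounds go, it remains open whether the methyl itself is needed, or whether a free amine, with only hydrogen on that nitrogen, or a longer chain such as ethyl would do as well. From the compounds shown here alone, it is also open whether this change has the same effect with the thiophen-2-yl of compound 2 on the other carbonyl.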